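Aryl selenocyanate carbamates: isobutyl to benzyl ester

A few compounds are considered here, and "the series" means these few. Any claim that something is new, unique, unknown or untested is made for them only; others in the source may bear on it.

Compound 1 `CC(C)COC(=O)Nc1ccc([Se]C#N)cc1` is tested in a functional assay on MCF7 cells (Homo sapiens) for cytotoxicity, read by MTT assay, with a stated time of 72 h (a lower number here means a stronger inhibitor of growth, a higher number a weaker inhibitor of growth), where compound 1 gives 45500 nM. Two diselenide carbamates sit alongside it: compound 2 `Cc1ccc(OC(=O)Nc2ccc([Se][Se]c3ccc(NC(=O)Oc4ccc(C)cc4)cc3)cc2)cc1` gives 37700 nM in this assay, and compound 3 `O=C(Nc1ccc([Se][Se]c2ccc(NC(=O)Oc3ccccc3)cc2)cc1)Oc1ccccc1` gives 36700 nM. Within the data shown here, the gaps from compound 1 to compound 2 and to compound 3 are both within the scatter, so the three numbers are not separated by the measurements at hand, and no step between them can be read as real.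

Compound 4 `N#C[Se]c1ccc(NC(=O)OCc2ccccc2)cc1` keeps the selenocyanate and the carbamate of compound 1 and differs only at the ester end: phenyl in place of isopropyl on a saturated chain carbon bound to an oxygen next to a carbonyl group. Among the measured compounds shown here, no measured pair in the set shows what this change does. For the measured compounds named here, with the three known numbers lying close together and no comparable step in hand, the expectation for the step from compound 1 to compound 4 in this assay is a 1.1-fold lower number from compound 1 to compound 4 (0.06 log units; within the scatter), that is, nothing beyond the scatter in either direction. Compound 4 is therefore expected to give about 40000 nM in this assay, with a range from 15000 nM to 110000 nM.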

Compound 4, concentration for total growth inhibition: 38800 nM
Compound 4: middle estimate off by 1.0-fold (0.01 log units), on the high side; the range from low to high includes it.
By their numbers in this assay, from the lowest: compounds 3, 2, 4 and 1 (each within the scatter of the next).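

Among these compounds, at the saturated chain carbon bound to an oxygen next to a carbonyl group, phenyl in place of isopropyl gives the only one-place step so far. In this assay it reads a 1.2-fold lower number from compound 1 to compound 4 (0.07 log units; within the scatter), so an aromatic ring at the ester end and the ringless isopropyl group are not separated by this measurement. Nothing at hand offers an explanation for this result.

From the compounds shown here alone, whether an amine, a carboxylic acid or a longer chain at this place would give a step beyond the scatter remains open. The selenocyanate and diselenide compounds differ in more than one place, and steps between them cannot be read.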